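Adding a methoxy group to the strongest modulator so far

The source may report more compounds than this note shows. Statements on the series, on what has been measured and on what is new or still open speak of the compounds shown alone.

Three compounds share a core with a long ether chain bridging two aromatic rings. Compound 1 `Cc1c(OCCCCOc2ccc(C(=O)O)cc2)ccc(C(=O)CC2CCCC2)c1O` gives 26.7% in an assay on HEK293 cells for positive allosteric modulation of metabotropic glutamate receptor 3 (Rattus norvegicus), read by thallium flux, with a stated time of 2.5 min; on this read-out lower numbers stand for smaller maximal responses and higher numbers for larger maximal responses. Compound 2 `CCC(=O)c1ccc(OCCCCOc2cc(C(=O)O)ccc2OC)c(C)c1O` gives 62.5% in this assay. Compound 3 `Cc1c(OCCCCOc2cccc(C(=O)O)c2)ccc(C(=O)CC2CCCC2)c1O` gives 92.9% in this assay, the highest of the three numbers, with compound 2 nearest and compound 1 furthest, both separated from it beyond the scatter. Among the compounds with values here, the one measured step, a number 66.2 percentage points higher from compound 1 to compound 3 (beyond the scatter), shows that moving the carboxy group on the aryl ring matters a great deal.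

Compound 4 `COc1ccc(C(=O)O)cc1OCCCCOc1ccc(C(=O)CC2CCCC2)c(O)c1C` is not yet measured. It differs from compound 3 by methoxy in place of hydrogen on an aromatic carbon; read one bond further out, the 3-carboxyphenyl ring becomes a 5-carboxy-2-methoxyphenyl ring. Within the data shown here, no measured step isolates this methoxy group. Compound 2 does carry the same 5-carboxy-2-methoxyphenyl ring, but it also differs from compound 3 elsewhere. That this ring can sit well below compound 3 is therefore only hinted at by compound 2 with its 62.5%. Compound 4 is therefore expected to give a smaller maximal response, with a step of a number 24.9 percentage points lower from compound 3 to compound 4 (beyond the scatter). The estimate for compound 4 is 68%, expected to fall between 45% and 92%.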

Compound 4, largest response reached (reported as percent of maximum), in percent of the reference or control that the assay uses: 67.6%
Compound 4: middle estimate off by 0.4 percentage points, on the high side; the measured number falls inside the stated range.
By their numbers in this assay, from the lowest: compound 1; then compounds 2 and 4 (each within the scatter of the next); then compound 3.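

Placing a methoxy group on the aromatic carbon ortho to a large group and para to a carboxy group lowers the response in this assay by a measured amount, with a number 25.3 percentage points lower from compound 3 to compound 4 (beyond the scatter) as the first step that isolates this one change. On the 5-carboxy-2-methoxyphenyl ring, cyclopentyl in place of methyl on the saturated chain carbon bound to a carbonyl carbon gives a number 5.1 percentage points higher from compound 2 to compound 4 (within the scatter) and so cannot be told apart from no change in this read-out. The methoxy-bearing ring still compares well with the 4-carboxyphenyl ring, giving a number 40.9 percentage points higher from compound 1 to compound 4 (beyond the scatter) in a single change at that same oxygen.

Nothing shown here explains why the methoxy group lowers the response. From the compounds shown here alone, it also remains open whether a fluorine atom, a hydroxy group or an ethoxy group on that same aromatic carbon would lower the response as much, and whether cyclopentyl and methyl would also match on the plain 3-carboxyphenyl ring.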